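Swapping a Naphthyl for a Tolyl on a Thiourea

The source may hold more compounds than are shown below. What is called first, only, known or untested is meant among the compounds shown, and "the series" means these compounds.

Compound 1 `NC(=O)c1c(NC(=O)c2ccccc2Cl)sc2c1CCNC2` is the simplest of the three. In a functional assay on MKN-74 cells (Homo sapiens) for antiproliferative activity, with a stated time of 24 h (on this read-out higher numbers stand for weaker inhibition and lower numbers for stronger inhibition), compound 1 gives 28700 nM. Compound 2 `NC(=O)c1c(NC(=O)c2ccccc2Cl)sc2c1CCN(C(=S)Nc1cccc3ccccc13)C2` adds a thiourea that carries a naphthalen-1-yl group; in this assay compound 2 gives 20700 nM. Within the data shown here, of the two numbers known so far, that of compound 2 is the lower one, but its gap to compound 1 lies within the scatter, so the two cannot be told apart on this read-out. Compound 3 `Cc1ccccc1NC(=S)N1CCc2c(sc(NC(=O)c3ccccc3Cl)c2C(N)=O)C1` has not yet been measured. It differs from compound 2 in one place: 2-methylphenyl in place of naphthalen-1-yl on an amide-type nitrogen. Among the measured compounds shown here, no measured pair shows what such a swap does. Since adding the whole naphthyl thiourea in compound 2 gave 20700 nM, a number indistinguishable from compound 1, a change confined to that same group is not expected to move the number beyond the scatter in either direction. Compound 3 is therefore expected to give 24000 nM in this assay, within a range of 8000 nM to 70000 nM, which amounts to an expected step of a 1.2-fold higher number from compound 2 to compound 3 (0.06 log units; within the scatter).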

Compound 3, half-maximal inhibitory concentration: 11700 nM
Compound 3: middle estimate off by 2.1-fold (0.31 log units), on the high side, within the range that was stated.
By their numbers in this assay, from the lowest: compounds 3, 2 and 1 (each within the scatter of the next, the first and the last beyond it).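

Replacing naphthalen-1-yl with 2-methylphenyl on the amide-type nitrogen removes one of the two aromatic rings, yet in this assay this gives a 1.8-fold lower number from compound 2 to compound 3 (0.25 log units; within the scatter) and so the two compounds cannot be told apart on this read-out. At this position, then, the full naphthalen-1-yl group is not needed to keep the number where it stands: a single six-membered aromatic ring with a methyl group does as well within the scatter. The comparison with the unsubstituted core adds something new: placing the group of compound 3 on the amine nitrogen in the ring gives a 2.5-fold lower number from compound 1 to compound 3 (0.39 log units; beyond the scatter) as a modest step that clears the scatter. Compound 2 goes against any general rule: its own gap to compound 1 stays within the scatter.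

As far as these compounds go, it remains open whether plain phenyl, or a ring carrying an amine or a carboxylic acid, would give a number that differs from compound 3 beyond the scatter. Nothing measured here accounts for the size of these steps.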